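Removing a Methyl from a Fused Bicyclic Core

This account rests on a few compounds, and the source may have more. Where it says the series, first, only, none or still open, it means among the compounds named here.

Compound 1 `CSc1nc2c(C)nsc2[nH]1` and compound 2 `CSc1nc2cnsc2[nH]1` share a core and differ by hydrogen in place of methyl on an aromatic carbon. In a functional assay on KB cells (Homo sapiens) for antiproliferative activity (on this read-out higher numbers stand for weaker inhibition and lower numbers for stronger inhibition), compound 1 gives 60000 nM, and compound 2 gives 15000 nM; that change is a 4.0-fold lower number from compound 1 to compound 2 (0.60 log units; beyond the scatter). Compound 3 `CSc1nc2c(C)nsc2n1[C@H]1C[C@H](O)[C@@H](CO)O1` carries the same methyl on a different core; how the two cores differ is not broken down here. For compound 3 the result in this assay is only a limit, > 100000 nM, which is the limit of > 100000 nM in this assay, at which 1 of the 3 values shown sits. Compound 4 `CSc1nc2cnsc2n1[C@H]1C[C@H](O)[C@@H](CO)O1` arises from compound 3 by hydrogen in place of methyl on an aromatic carbon, the same change as that between compound 1 and compound 2. Since compound 3 is known only as a limit, the starting point is uncertain. The step expected here is an at least 1.2-fold lower number from compound 3 to compound 4 (0.09 log units; that floor lies within the scatter), because the measured change a 4.0-fold lower number from compound 1 to compound 2 (0.60 log units; beyond the scatter) went the same way. For compound 4 the expected value in this assay is 80000 nM, quite possibly reported again only as a limit.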

Compound 4, half-maximal inhibitory concentration: > 100000 nM
Compound 4 gave a limit, no number; the forecaster's own chance of this, stated with the estimate: 55%; middle value at least 1.2-fold (0.09 log units) away from the limit.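

Compound 3 and compound 4 both give only a limit in this assay, so the step between them cannot be read: the limit of > 100000 nM in this assay, at which 2 of the 4 values shown sit.

From the compounds shown here alone, whether hydrogen in place of methyl lowers the number on the core of compound 3, as it does on the core of compound 1, stays open.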